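Shifting the Bromine Around the Phenyl Ring

A few compounds are considered here, and "the series" means these few. Any claim that something is new, unique, unknown or untested is made for them only; others in the source may bear on it.

Compound 1, `O[C@H]1CCCC[C@@H]1N1CCN(CCCc2ccccc2Br)CC1`, gives 19.4 nM in an assay on membranes from cerebrum (strain Sprague-Dawley) for displacement of a labelled ligand from Sigma non-opioid intracellular receptor 1 (Rattus norvegicus), read by scintillation counting, with a stated time of 90 min; a higher number here means a weaker inhibitor, a lower number a stronger inhibitor.
Compound 2, `O[C@H]1CCC[C@@H]1N1CCN(CCCc2ccccc2Br)CC1`, gives 37.1 nM in this assay.

Within the data shown here, of the two numbers measured, compound 2 has the higher one, and the only measured step, a 1.9-fold higher number from compound 1 to compound 2 (0.28 log units; within the scatter), concerns the hydroxylated ring on the amine nitrogen and lies within the scatter. Compound 3, `O[C@H]1CCC[C@@H]1N1CCN(CCCc2ccc(Br)cc2)CC1`, differs from compound 2 by 4-bromophenyl in place of 2-bromophenyl on a saturated chain carbon, three bonds along the chain from an amine nitrogen in a ring. Among the measured compounds shown here, no measured step touches the bromophenyl group, so nothing here gives a size or direction for this change. The expectation for compound 3 is therefore a step of a 1.2-fold lower number from compound 2 to compound 3 (0.09 log units; within the scatter), judged as not clearly beyond the scatter. Compound 3 is estimated at 30 nM, in a range of 8 nM to 120 nM.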

Compound 3, inhibition constant: 8.1 nM
The estimate for compound 3 lay 3.7-fold (0.57 log units) above the measured number; low and high end bracket the measured number.
By their numbers in this assay, from the lowest: compound 3; then compounds 1 and 2 (each within the scatter of the next).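

Moving the bromine gives a 4.6-fold lower number from compound 2 to compound 3 (0.66 log units; beyond the scatter) in this assay and is the first step here to lie beyond the scatter, though it is modest in size. The two groups hold the same atoms, so only the place of the bromine on the phenyl ring separates compound 2 from compound 3. No available evidence bears on why this change lowers the number.

As far as these compounds go, whether 4-bromophenyl also lowers the number when the 2-hydroxycyclohexyl group of compound 1 is present remains open. So does the outcome with 3-bromophenyl, 4-chlorophenyl or a longer chain.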